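Azole swap on a potent serotonin receptor ligand

The source may hold more compounds than are shown below. What is called first, only, known or untested is meant among the compounds shown, and "the series" means these compounds.

Measured so far:
compound 1, `OC[C@H](NC1CCN(CCCc2c[nH]c3ccc(-n4ccnc4)cc23)CC1)c1ccccc1` — 0.7 nM
compound 2, `CNS(=O)(=O)Cc1ccc2[nH]cc(CCCN3CCC(N[C@H](C)c4ccccc4)CC3)c2c1` — 43 nM

In an assay on CHO cells for displacement of a labelled ligand from 5-hydroxytryptamine receptor 1D (Homo sapiens) (on this read-out lower numbers stand for stronger inhibition and higher numbers for weaker inhibition), compound 1 gives 0.7 nM, the lowest of the two numbers recorded. Compound 2, which carries a different core and a different substituent on the benzenoid ring of that core, gives 43 nM in this assay; the gap between these two compounds lies well beyond the scatter of the measurement, so compound 1 is the stronger binder of the pair. No single-point change between measured compounds is available, so the two values can only be compared as they stand.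

Going by the values given here, compound 3, `OC[C@H](NC1CCN(CCCc2c[nH]c3ccc(-n4cncn4)cc23)CC1)c1ccccc1`, is the one unmeasured compound. It differs from compound 1 by 1H-1,2,4-triazol-1-yl in place of 1H-imidazol-1-yl on an aromatic carbon. Among the compounds with values here, with no measured step of this kind to lean on, the expectation rests on the small size of the change: one ring nitrogen in place of one ring carbon, with the rest of the molecule unchanged. A step from compound 1 to compound 3 of about a 2.1-fold higher number from compound 1 to compound 3 (0.33 log units; beyond the scatter) in this assay is expected, leaning toward a slightly higher number but possibly none beyond the scatter. Compound 3 is therefore estimated at 1.5 nM in this assay, with a range from 0.5 nM to 5 nM.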

Compound 3, half-maximal inhibitory concentration: 4.1 nM
Estimate against measurement, compound 3: 2.7-fold (0.44 log units) below; measured number inside the range.
By their numbers in this assay, from the lowest: compound 1; then compound 3; then compound 2.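

In this assay, replacing 1H-imidazol-1-yl with 1H-1,2,4-triazol-1-yl on the aromatic carbon gives a 5.9-fold higher number from compound 1 to compound 3 (0.77 log units; beyond the scatter). Going by these compounds alone, this is the first single-place comparison in the set, and it shows that the read-out at this position responds to one ring nitrogen taking the place of one ring carbon, even though the two groups have the same number of heavy atoms and neither carries a net charge. The change is modest, however, and compound 3 still gives a low number, 4.1 nM, so the 1H-1,2,4-triazol-1-yl group is accommodated here with only a limited loss of inhibition. Nothing presented here explains why the added ring nitrogen moves the number in this direction.

The compounds shown leave open how other groups would behave on this aromatic carbon, such as 1H-tetrazol-1-yl, with a further ring nitrogen, or an open-chain primary amide. They also leave open whether the same azole swap would produce a step of similar size if the hydroxymethyl group on the side chain of compound 1 were replaced by a methyl group.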